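Bromo in place of fluoro: working notes

The compounds below may be only part of what the source reports. "The series", "measured", "known", "first", "only" and "open" are said of these compounds alone.

Measured in a functional assay on SMMC-7721 cells (Homo sapiens) for cytotoxicity, read by MTT assay, with a stated time of 72 h; a lower number here means a stronger inhibitor, a higher number a weaker inhibitor:
- compound 1 `CN(C)c1ccc(C=C2C(=O)N(c3ccc(Cl)cc3)N(c3ccc(Cl)cc3)C2=O)cc1`: > 128000 nM, a limit and not a number
- compound 2 `O=C1C(=Cc2ccc(F)cc2)C(=O)N(c2ccc(Cl)cc2)N1c1ccc(Cl)cc1`: 23300 nM

For the measured compounds named here, compound 2 gives the only actual number so far, 23300 nM. Compound 1 sits at the limit of > 128000 nM in this assay, at which 1 of the 2 values shown sits. Compound 3 `O=C1C(=Cc2ccc(Br)cc2)C(=O)N(c2ccc(Cl)cc2)N1c1ccc(Cl)cc1` carries bromo in place of fluoro on an aromatic carbon, para to a large group (bromo in place of fluoro on an aromatic carbon). Going by the values given here, the only measured step is an at least 5.4-fold lower number from compound 1 to compound 2 (0.73 log units; beyond the scatter), with fluoro in place of dimethylamino. Among the compounds with values here, it shows that this place can move the number in this assay, but no measured step compares bromo with fluoro. The expected step is small, within the scatter: a 1.2-fold lower number from compound 2 to compound 3 (0.07 log units; within the scatter). For compound 3 the estimate is 20000 nM, with an expected range of 8000 nM to 50000 nM.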

Compound 3, half-maximal inhibitory concentration: 16600 nM
Compound 3: the middle estimate sits 1.2-fold (0.08 log units) above what was measured, and the stated range covers the measured number.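

In this assay, the step is a 1.4-fold lower number from compound 2 to compound 3 (0.15 log units; within the scatter), so 4-fluorophenyl and 4-bromophenyl cannot be told apart at this position. Bromo in place of dimethylamino gives an at least 7.7-fold lower number from compound 1 to compound 3 (0.88 log units; beyond the scatter), so a second halogen now separates from dimethylamino, not fluoro alone. Compound 1 remains a limit and not a number: the limit of > 128000 nM in this assay, at which 1 of the 3 values shown sits.

Going by these compounds, whether a nitrile, a methoxy or a carboxylic acid at this position would track the halogens or dimethylamino stays open. On these data alone, the true size of the gap between dimethylamino and either halogen also stays open.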